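A few compounds are considered here, and "the series" means these few. Any claim that something is new, unique, unknown or untested is made for them only; others in the source may bear on it.

Compound 1: `O=C1COc2ccc(-c3cnc(Cl)c(NS(=O)(=O)c4ccc(F)cc4)c3)cc2N1c1ccc(F)cc1` — > 40000 nM
Compound 2: `CC(C)N1C(=O)COc2ccc(-c3cnc(Cl)c(NS(=O)(=O)c4ccc(F)cc4)c3)cc21` — 5380 nM
Compound 3: `COc1ccc(N2C(=O)COc3ccc(-c4cnc(Cl)c(NS(=O)(=O)c5ccc(F)cc5)c4)cc32)cc1` — 8320 nM

The three measured compounds share one core and differ only in the group on the amide-type nitrogen in the ring. In a functional assay on HeLa cells (Homo sapiens) for antiproliferative activity, read by MTT assay, with a stated time of 72 h (a higher number here means a weaker inhibitor, a lower number a stronger inhibitor), compound 1 reaches only a limit of the assay, > 40000 nM. Compound 2 gives 5380 nM, the lowest of the two numbers, and compound 3 gives 8320 nM, a step of a 1.5-fold higher number from compound 2 to compound 3 (0.19 log units; within the scatter). The two steps from compound 1, an at least 7.4-fold lower number from compound 1 to compound 2 (0.87 log units; beyond the scatter) and an at least 4.8-fold lower number from compound 1 to compound 3 (0.68 log units; beyond the scatter), are both bounded by the limit (the limit of > 40000 nM in this assay, at which 1 of the 3 values shown sits).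

Compound 4, `COc1ncc(-c2ccc3c(c2)N(C(C)C)C(=O)CO3)cc1NS(=O)(=O)c1ccc(F)cc1`, is not yet measured. It differs from compound 2 by methoxy in place of chloro on an aromatic carbon. Going by the values given here, none of the measured steps touches this part of the core; all three concern the group on the amide-type nitrogen. Among the compounds with values here, there is therefore no measured step to lean on, and the expectation for compound 4 is a step of a 1.3-fold higher number from compound 2 to compound 4 (0.11 log units; within the scatter), not beyond the scatter in either direction. Compound 4 is estimated at 7000 nM, within 2500 nM to 25000 nM.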

Compound 4, half-maximal inhibitory concentration: 2790 nM
Compound 4: the middle estimate sits 2.5-fold (0.40 log units) above what was measured, within the range that was stated.
By their numbers in this assay, from the lowest: compounds 4, 2 and 3 (each within the scatter of the next, the first and the last beyond it). At a limit, above all of these: compound 1.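

Compounds 1, 2 and 3 all carry chloro on the aromatic carbon next to the ring nitrogen, so they said nothing about this position, only about the group on the amide-type nitrogen. In this assay, methoxy in place of chloro gives a 1.9-fold lower number from compound 2 to compound 4 (0.29 log units; within the scatter), which shows that, with isopropyl on the amide-type nitrogen, this position accepts a group with one more heavy atom and a hydrogen-bond acceptor without a step beyond the scatter. Nothing measured here gives a reason for this result.

As far as these compounds go, it remains open whether an amine, a nitrile or a longer chain such as ethoxy at this position would also stay within the scatter of compound 2. From the compounds shown here alone, it is also open whether methoxy behaves the same way with 4-methoxyphenyl on the amide-type nitrogen.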